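The source may report more compounds than this note shows. Statements on the series, on what has been measured and on what is new or still open speak of the compounds shown alone.

Measured compounds: compound 1 `O[C@H](c1ccccn1)[C@]1(c2ccc(C(F)(F)F)cc2)C[C@@H](O)C1` with 1870 nM; compound 2 `O[C@H](c1ccccn1)[C@]1(c2ccc(Cl)c(Cl)c2)CCO1` with 150 nM; compound 3 `C[C@]1(O)C[C@@](c2ccc(C(F)(F)F)cc2)([C@H](O)c2ccccn2)C1` with 840 nM.

All three were tested in an assay on HEK293 cells for antagonist activity at transient receptor potential cation channel subfamily V member 3 (Homo sapiens), read by FLIPR and calcium flux; a higher number here means a weaker inhibitor, a lower number a stronger inhibitor. Among them compound 1 gives the highest number, so it is the weakest inhibitor of the three. Compound 4 `O[C@H](c1ccccn1)[C@]1(c2ccc(C(F)(F)F)cc2)C[C@H](O)C1` differs from compound 1 only in the spatial arrangement of its ring: the two compounds have the same atoms and bonds and differ only in configuration as drawn: 2 of 3 stereo elements differ; a stereocentre at a saturated ring carbon is drawn r in compound 1 and s in compound 4; a stereocentre at a saturated ring carbon is drawn S in compound 1 and R in compound 4. Going by the values given here, the one step recorded so far, a 2.2-fold lower number from compound 1 to compound 3 (0.35 log units; beyond the scatter), adds a group rather than changing configuration, so it does not bear on this change. Nothing measured here shows how such a flip affects this assay, so the step from compound 1 to compound 4 is expected to be small, as a 1.2-fold lower number from compound 1 to compound 4 (0.10 log units; within the scatter), with wide uncertainty in either direction. Compound 4 is therefore estimated at 1500 nM, plausibly between 400 nM and 6000 nM.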

Compound 4, antagonist equilibrium constant: 2240 nM
Compound 4: the middle estimate sits 1.5-fold (0.17 log units) below what was measured; measured number inside the range.
By their numbers in this assay, from the lowest: compound 2; then compound 3; then compounds 1 and 4 (each within the scatter of the next).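

Going by these compounds alone, compounds 1 and 4 give the first comparison here that isolates configuration, and its basis is plain: the fact that compounds 1 and 4 differ only in the configuration as drawn. In this assay the step is a 1.2-fold higher number from compound 1 to compound 4 (0.08 log units; within the scatter), so this assay does not separate the two arrangements in this pair. Within the data shown here, the only earlier step, to compound 3, added a methyl and left this question untouched.

As far as these compounds go, whether the same holds with that methyl present, or for the third stereo element, which stayed the same here, remains open. So does how an amine or a carboxylic acid in place of the ring hydroxyl would behave.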